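Aryl swap on the benzylthio arm: cytotoxicity notes

The source may report more compounds than this note shows. Statements on the series, on what has been measured and on what is new or still open speak of the compounds shown alone.

Measured so far:
compound 1 `COc1cc(-c2nnc(SCc3ccc(Cl)cc3)o2)ccc1O` — 480000 nM
compound 2 `COc1cc(-c2nnc(SCc3ccc(F)cc3)o2)ccc1O` — 685000 nM

In an ADME assay on cells (Mus musculus, strain BALB/c) for cytotoxicity, read by MTT assay, with a stated time of 24 h (a lower number here means that less compound is tolerated, a higher number that more compound is tolerated), compound 1 gives 480000 nM and compound 2 gives 685000 nM. Within the data shown here, the only measured step, a 1.4-fold higher number from compound 1 to compound 2 (0.15 log units; within the scatter), stays within the scatter, so the two values show no ordering, and compound 2 cannot be called better tolerated than compound 1. Compound 2 stands at the higher of the two numbers, with compound 1 as its nearest neighbour within the scatter.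

Compound 3 `COc1cc(-c2nnc(SCc3ccccc3C)o2)ccc1O` is not yet measured in this assay. Its change from compound 2 is 2-methylphenyl in place of 4-fluorophenyl on a saturated chain carbon bound to a sulfur. Among the measured compounds shown here, the one step that bears on it, a 1.4-fold higher number from compound 1 to compound 2 (0.15 log units; within the scatter), is a change on the same aromatic ring and did not move the number beyond the scatter. Compound 3 is therefore expected to give a step of a 1.1-fold lower number from compound 2 to compound 3 (0.06 log units; within the scatter), not beyond the scatter, with an estimated value of 600000 nM and a range from 300000 nM to 1200000 nM.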

Compound 3, half-maximal cytotoxic concentration: 592000 nM
For compound 3 the middle estimate is 1.0-fold (0.01 log units) above the measured one; the measured number falls inside the stated range.
By their numbers in this assay, from the lowest: compounds 1, 3 and 2 (each within the scatter of the next).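

In this assay the earlier pair differed only in the halogen on the aromatic ring, whereas this change replaces 4-fluorophenyl with 2-methylphenyl on a saturated chain carbon bound to a sulfur, and a 1.2-fold lower number from compound 2 to compound 3 (0.06 log units; within the scatter) is the result. Set against 4-chlorophenyl, the same group gives a 1.2-fold higher number from compound 1 to compound 3 (0.09 log units; within the scatter) as its step, so compound 1, compound 2 and compound 3 cannot be ordered, and a halogen on this ring is not required for tolerance in this range among these three. No measurement is available that accounts for these numbers.

The compounds shown leave open whether any group at this position moves the number beyond the scatter, for example an aromatic ring carrying an amine or a carboxylic acid, or a longer chain in place of the ring. They also say nothing about changes elsewhere on the shared core.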